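The source may report more compounds than this note shows. Statements on the series, on what has been measured and on what is new or still open speak of the compounds shown alone.

In a functional assay on HT-1080 cells (Homo sapiens) for antiproliferative activity, read by MTT assay (a lower number here means a stronger inhibitor, a higher number a weaker inhibitor), compound 1 `Cc1cc(=O)c(O)c(Cc2ccc(F)cc2)o1` gives > 50000 nM, which is a limit and not a number. Compound 2 `Cc1cc(=O)c(O)c(Cc2ccc(C(F)(F)F)cc2)o1` gives 24400 nM, and compound 3 `Cc1cc(=O)c(O)c(C(c2ccc(OCc3ccc([N+](=O)[O-])cc3)cc2)c2oc(C)cc(=O)c2O)o1` gives 3060 nM, the lower of the two actual numbers.

Compound 4 `CCCOc1ccc(C(c2oc(C)cc(=O)c2O)c2oc(C)cc(=O)c2O)cc1` has not yet been measured. It differs from compound 3 by ethyl in place of 4-nitrophenyl on a saturated chain carbon bound to an oxygen on an aromatic ring. This is ethyl in place of 4-nitrophenyl on a saturated chain carbon bound to an oxygen on an aromatic ring, so (4-nitrobenzyl)oxy becomes propoxy.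

For the measured compounds named here, only one measured step is available as a guide: an at least 2.0-fold lower number from compound 1 to compound 2 (0.31 log units; beyond the scatter), brought by trifluoromethyl in place of fluoro on an aromatic carbon. That swap lies elsewhere in the structure, so it bears only loosely and merely suggests that a single group change can shift these numbers modestly. With compound 3 already at 3060 nM, a modest move to a higher number seems the likelier outcome. The expected step in this assay is a 2.0-fold higher number from compound 3 to compound 4 (0.29 log units; within the scatter). For compound 4 the estimated value is 6000 nM, with an expected range from 1800 nM to 20000 nM.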

Compound 4, half-maximal inhibitory concentration: 26600 nM
Estimate against measurement, compound 4: 4.4-fold (0.65 log units) below, outside the stated range (above it).
By their numbers in this assay, from the lowest: compound 3; then compounds 2 and 4 (each within the scatter of the next). At a limit, above all of these: compound 1.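

In this assay, replacing 4-nitrophenyl with ethyl on a saturated chain carbon bound to an oxygen on an aromatic ring gives an 8.7-fold higher number from compound 3 to compound 4 (0.94 log units; beyond the scatter). For the compounds shown here, this is the first measured change at this place, and it shows that the number responds to what sits there: the earlier step concerned only a group on an aromatic carbon elsewhere in the structure. Nothing measured here gives a reason for this step.

The change removes the nitro group and an aromatic ring together, so the compounds shown do not tell which of the two matters, or whether the overall size of the group does. A plain benzyl group would separate the ring from the nitro group, and a longer chain in place of propyl would show how this number follows chain length.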